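Sec-Butyl for Isobutyl on a Second Core

This account rests on a few compounds, and the source may have more. Where it says the series, first, only, none or still open, it means among the compounds named here.

Two compounds with a shared core open the series. Compound 1 `CC(C)COc1ccccc1-c1ncc(C(=O)O)c(=O)[nH]1` carries an isobutyl group on an oxygen on an aromatic ring; compound 2 `CCC(C)Oc1ccccc1-c1ncc(C(=O)O)c(=O)[nH]1` carries a sec-butyl group there instead. In a functional assay on the whole organism (strain Sprague-Dawley) for inhibition, with Rattus norvegicus as the target, with a stated time of 10 min (on this read-out higher numbers stand for an effect only at larger amounts of compound and lower numbers for an effect already at smaller amounts), compound 1 gives 0.5 mg/kg, and compound 2 gives 0.5 mg/kg. The change between them is sec-butyl in place of isobutyl on an oxygen on an aromatic ring, and it left the read-out where it was: no change at the digits printed from compound 1 to compound 2 (within the scatter).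

Compound 3 `CCOC(=O)c1cnc(-c2ccccc2OCC(C)C)[nH]c1=O` keeps the isobutyl ether of compound 1, but its core differs by ethyl in place of hydrogen on an oxygen next to a carbonyl group. In this assay compound 3 gives 3 mg/kg, and the step is a 6.0-fold higher number from compound 1 to compound 3 (0.78 log units; beyond the scatter).

Compound 4 `CCOC(=O)c1cnc(-c2ccccc2OC(C)CC)[nH]c1=O` has not yet been measured. Among the measured compounds shown here, it stands to compound 3 as compound 2 stands to compound 1: the difference is sec-butyl in place of isobutyl on an oxygen on an aromatic ring, the same change at the same place as the one already seen between compound 1 and compound 2. That earlier step, no change at the digits printed from compound 1 to compound 2 (within the scatter), stayed within the scatter of the measurement. For the measured compounds named here, on the core of compound 3 no second example of this swap exists, so the expectation rests on that one pair alone. The step from compound 3 to compound 4 in this assay is therefore expected to be no change at the digits printed from compound 3 to compound 4 (within the scatter), close to nothing, because the matching step no change at the digits printed from compound 1 to compound 2 (within the scatter) showed no movement. Compound 4 is estimated at 3 mg/kg, with a likely range from 1.5 mg/kg to 6 mg/kg.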

Compound 4, dose for 50% inhibition: 0.5 mg/kg
The estimate for compound 4 lay 6.0-fold (0.78 log units) above the measured number; measured number below the stated range.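

On the core of compound 3, the swap of isobutyl for sec-butyl gives a 6.0-fold lower number from compound 3 to compound 4 (0.78 log units; beyond the scatter) in this assay, so a change that left the read-out in place on the core of compound 1 does not carry over unchanged to this second core: the same change on two cores in this assay, no change at the digits printed (within the scatter) from compound 1 to compound 2 and a 6.0-fold lower number (0.78 log units; beyond the scatter) from compound 3 to compound 4, 6.0-fold (0.78 log units) apart, beyond the scatter of two such steps

Read along the other edge of the same set of four compounds, ethyl in place of hydrogen on an oxygen next to a carbonyl group gives no change at the digits printed from compound 2 to compound 4 (within the scatter), so the cost of that change seen with the isobutyl ether does not appear with the sec-butyl ether: the same change on two cores in this assay, a 6.0-fold higher number (0.78 log units; beyond the scatter) from compound 1 to compound 3 and no change at the digits printed (within the scatter) from compound 2 to compound 4, 6.0-fold (0.78 log units) apart, beyond the scatter of two such steps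

Compound 1, compound 2 and compound 4 print the same number and compound 3 alone stands apart, which shows that the two changes do not simply add up here, but with one pair on each core it does not show why, nor whether the same would hold for any other ether group.

The compounds shown leave open how a longer chain such as n-pentyl, or a ring such as cyclopentyl, would behave on that oxygen on each core. They also leave open whether an amide in place of the carboxylic acid or the ethyl ester would follow compound 2 or compound 3.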